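This account rests on a few compounds, and the source may have more. Where it says the series, first, only, none or still open, it means among the compounds named here.

Measured compounds:
Compound 1, `CSc1ccc(C)cc1NCC1=NCCN1`: 200 nM
Compound 2, `CS(=O)(=O)c1ccc(Cl)cc1NCC1=NCCN1`: 4790 nM

Both compounds were tested in an assay on CHO cells for binding affinity to Alpha-2C adrenergic receptor (Homo sapiens), read by radioligand binding; on this read-out lower numbers stand for stronger inhibition and higher numbers for weaker inhibition. Of the two numbers, compound 2 holds the higher one, and its nearest neighbour is compound 1, whose number is far lower, a gap well beyond the scatter. Compound 2 is therefore the weaker binder of the pair measured so far.

Compound 3, `Cc1ccc(S(C)(=O)=O)c(NCC2=NCCN2)c1`, has not yet been tested in this assay. It is derived from compound 2 by a single change: methyl in place of chloro on an aromatic carbon. The group that leaves and the group that enters are each a single heavy atom, neither carries a donor or acceptor, and the place on the aromatic ring, para to a methylsulfonyl group, stays the same.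

Among the measured compounds shown here, no measured pair in this set differs by only this change, so there is nothing to lean on directly. A swap of one small uncharged atom for another on a ring is expected to move the number only modestly in this assay, if beyond the scatter at all. The step from compound 2 to compound 3 is estimated as a 1.6-fold lower number from compound 2 to compound 3 (0.20 log units; within the scatter). For compound 3 the expected value is 3000 nM, within a range from 1000 nM to 9000 nM.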

Compound 3, inhibition constant: < 5020 nM
Compound 3 gave a limit, no number; the forecaster's own chance of this, stated with the estimate: 5%; the middle value does not contradict the limit.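

In this assay compound 3 gives < 5020 nM, which is a limit and not a number. The steps to compound 3 from compound 2 and from compound 1 therefore cannot be read. The compounds shown leave open how strongly compound 3 binds, and so whether methyl in place of chloro, or methylsulfonyl in place of methylsulfanyl, moves the number at all.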